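One Stereocentre Inverted: What Happens to Cytotoxicity?

The source may report more compounds than this note shows. Statements on the series, on what has been measured and on what is new or still open speak of the compounds shown alone.

Three related compounds have been tested so far in a functional assay on Vero cells (Chlorocebus sabaeus) for cytotoxicity; on this read-out lower numbers stand for stronger inhibition and higher numbers for weaker inhibition. Here compound 3 `O=c1[nH]c(=O)n([C@@H]2C=C[C@@H](CO)O2)cc1F` gives 3000 nM, the lowest number among them. Compound 1 `O=C1NC(O)C(F)=CN1[C@H]1C=C[C@@H](CO)O1` gives 7900 nM, a higher number, and this gap to compound 3 lies beyond the usual scatter. Compound 2 `Nc1nc(=O)n([C@H]2C=C[C@@H](CO)O2)cc1Br` gives > 100000 nM, which is a limit of the assay and not a number.

The next candidate is compound 4 `O=c1[nH]c(=O)n([C@@H]2C=C[C@H](CO)O2)cc1F`. Set against compound 3, it differs as follows: the two compounds have the same atoms and bonds and differ only in configuration as drawn: 1 of 2 stereo elements differ; a stereocentre at a saturated ring carbon is drawn S in compound 3 and R in compound 4. Such a pair has the same connections but a different arrangement in space. For the measured compounds named here, no measured pair here shows what this kind of change does, so any expectation is loose. Compound 3, at 3000 nM, already sits lowest, so a move towards a higher number, meaning weaker inhibition, seems likelier than a move lower. The expected size of the change is a 4.0-fold higher number from compound 3 to compound 4 (0.60 log units; beyond the scatter). For compound 4 the estimate in this assay is 12000 nM, within an expected range of 2500 nM to 60000 nM.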

Compound 4, half-maximal inhibitory concentration: 32000 nM
Compound 4: the middle estimate sits 2.7-fold (0.43 log units) below what was measured; the measured number falls inside the stated range.
By their numbers in this assay, from the lowest: compound 3; then compound 1; then compound 4. At a limit, above all of these: compound 2.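

The step shows that in this assay the arrangement in space at this one saturated ring carbon matters a great deal: the change is an 11-fold higher number from compound 3 to compound 4 (1.03 log units; beyond the scatter), which counts as large. For the compounds shown here, the earlier compounds offered no pair that differed in one place, so this is the first direct reading of any single change. With no atom or bond altered, the shift can be tied to the stereocentre drawn S in compound 3 and R in compound 4 alone, because of this: the fact that compounds 3 and 4 differ only in the configuration as drawn

From the compounds shown here alone, whether inverting this centre would have a similar effect with a carboxylic acid or a longer chain on the shared core remains open. Compound 2 gives > 100000 nM, which is a limit of the assay and not a number, so it offers no measured size for comparison.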